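The source may hold more compounds than are shown below. What is called first, only, known or untested is meant among the compounds shown, and "the series" means these compounds.

Working notes on the series, read in a functional assay on MDA-MB-231 cells (Homo sapiens) for inhibition, read by MTT assay, with a stated time of 48 h; a higher number here means a weaker inhibitor, a lower number a stronger inhibitor. Compound 1 (`COc1ccc(-c2nc3ccccn3c2Sc2ccccc2)cc1`) gives > 100000 nM, which is a limit of the assay and not a number. For the measured compounds named here, compound 2 (`c1ccc(Sc2c(-c3ccccc3)nc3ccc(-c4ccccc4)cn23)cc1`) gives 76700 nM, the only true number so far. Going by the values given here, the series therefore has (the limit of > 100000 nM in this assay, at which 1 of the 2 values shown sits), and no step between measured compounds can be read from it.

The next compound is compound 3 (`Clc1ccc(-c2nc3ccccn3c2Sc2ccccc2)cc1`). The change is chloro in place of methoxy on an aromatic carbon, para to a large group, so that 4-methoxyphenyl becomes 4-chlorophenyl. Among the compounds with values here, no measured step covers this change, so any expectation is weakly grounded. The expectation stays close to compound 1, whose > 100000 nM is a limit and offers no exact starting point. No shift beyond the usual scatter is expected in either direction, and a second reading at the limit is quite possible. The expected size of the change is an at least 1.1-fold lower number from compound 1 to compound 3 (0.07 log units; that floor lies within the scatter). For compound 3 the estimated value is 85000 nM, with an expected range from 35000 nM to 200000 nM.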

Compound 3, half-maximal inhibitory concentration: 24500 nM
For compound 3 the middle estimate is 3.5-fold (0.54 log units) above the measured one; measured number below the stated range.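

For the compounds shown here, at this aromatic carbon, para to a large group, the substituent has a readable effect in this assay: the change from 4-methoxyphenyl to 4-chlorophenyl gives the first step beyond the scatter (an at least 4.0-fold lower number from compound 1 to compound 3 (0.61 log units; beyond the scatter)). As far as these compounds go, compound 1 gives (> 100000 nM), which is a limit and not a number, so the step is only a floor and its true size stays unknown because one end of it rests on that limit: (the limit of > 100000 nM in this assay, at which 1 of the 3 values shown sits). Compound 3 gives (24500 nM), so this position now has an exact starting point, which compound 1 could not provide.

From the compounds shown here alone, whether the step belongs to chloro in particular or would follow from other replacements of methoxy stays open, and an amine, a carboxylic acid, a trifluoromethyl or a fluoro at the same carbon, read against compound 3, would bear on that. Compound 2 differs from compound 3 in more than one place, so no step can be read between them and the steps to the rest of the shared core remain unresolved.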